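Moving the fluorine around the ring on a triazole series

The source may report more compounds than this note shows. Statements on the series, on what has been measured and on what is new or still open speak of the compounds shown alone.

Three compounds share one core, differing only in the group carried on an aromatic carbon of the triazole. Compound 1 `CCCc1cn(C(c2ccccc2)c2cc3cc(Br)ccc3nc2OC)nn1` carries propyl there, compound 2 `COc1nc2ccc(Br)cc2cc1C(c1ccccc1)n1cc(-c2ccccc2C(F)(F)F)nn1` a 2-(trifluoromethyl)phenyl and compound 3 `COc1nc2ccc(Br)cc2cc1C(c1ccccc1)n1cc(-c2cccc(F)c2)nn1` a 3-fluorophenyl. In an ADME assay on SK-OV-3 cells (Homo sapiens) for cytotoxicity, read by sulforhodamine B assay, with a stated time of 48 h, tested at 10 uM (on this read-out lower numbers stand for less inhibition and higher numbers for more inhibition at the one concentration tested (going by the name of the read-out)), compound 1 gives 11.2%, compound 2 gives 9.55% and compound 3 gives 12.7%. On these numbers compound 3 sits at the top of the three, but the steps of a number 1.5 percentage points higher from compound 1 to compound 3 (within the scatter) and a number 3.2 percentage points higher from compound 2 to compound 3 (within the scatter) are both within the scatter, as is a number 1.7 percentage points lower from compound 1 to compound 2 (within the scatter), so the three cannot be told apart.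

Compound 4 `COc1nc2ccc(Br)cc2cc1C(c1ccccc1)n1cc(-c2ccc(F)cc2)nn1` has not yet been measured. It differs from compound 3 by 4-fluorophenyl in place of 3-fluorophenyl on an aromatic carbon. Among the measured compounds shown here, the steps that bear on this change are the ones at the same aromatic carbon, from propyl to 2-(trifluoromethyl)phenyl, from propyl to 3-fluorophenyl and from 2-(trifluoromethyl)phenyl to 3-fluorophenyl, and none of them moved the percentage inhibition beyond the scatter. Because a number 3.2 percentage points higher from compound 2 to compound 3 (within the scatter) was so small, no step beyond the scatter is expected for a swap between two fluorophenyl groups. The expected step is a number 0.7 percentage points lower from compound 3 to compound 4 (within the scatter). Compound 4 is therefore estimated at 12%, with a range from 4% to 21%.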

Compound 4, a percentage reported as inhibition, at one concentration (the size of the read-out at that concentration, not a potency): 14.3%
Estimate against measurement, compound 4: 2.3 percentage points below; low and high end bracket the measured number.
By their numbers in this assay, from the lowest: compounds 2, 1, 3 and 4 (each within the scatter of the next).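

Moving the fluorine from 3-fluorophenyl to 4-fluorophenyl keeps the same atoms and changes only how they are joined, and in this assay this swap gives a number 1.6 percentage points higher from compound 3 to compound 4 (within the scatter) and so shows no readable response at this aromatic carbon to where the fluorine sits on the phenyl ring. Set against the other two groups, the new compound gives a number 4.8 percentage points higher from compound 2 to compound 4 (within the scatter) and a number 3.1 percentage points higher from compound 1 to compound 4 (within the scatter), so the propyl chain and all three substituted phenyl groups at this position still cannot be told apart. Nothing measured here offers a reason for this flat picture.

The compounds shown leave open whether any group at this carbon can shift the percentage inhibition beyond the scatter, for instance an amine or a carboxylic acid in place of the propyl chain or the fluorinated phenyl rings. Going by these compounds, the bromine and the methoxy group are the same in all four compounds, so what a change at either place would do to the number also remains open.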